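Adding trifluoromethyl to compound 3

The compounds below may be only part of what the source reports. "The series", "measured", "known", "first", "only" and "open" are said of these compounds alone.

Measured so far in an ADME assay on BE(2)-C cells (Homo sapiens) for cytotoxicity, read by MTT assay, with a stated time of 20 h; on this read-out higher numbers stand for lower toxicity in this test and lower numbers for higher toxicity in this test
- compound 1 `CN(Cc1ccccc1)C(=O)C1CCN(C(=O)c2cc3ccccc3n2Cc2ccc(Cl)cc2)CC1` gives 87000 nM
- compound 2 `COc1ccc(Cn2c(C(=O)N3CCC(C(=O)N(C)Cc4ccccc4)CC3)cc3ccccc32)cc1` gives 99200 nM
- compound 3 `CN(Cc1ccccc1)C(=O)C1CCN(C(=O)c2cc3ccccc3n2Cc2ccccc2)CC1` gives 64800 nM

Compound 3 stands within the scatter of both compound 1 and compound 2, so the three numbers cannot be ranked. The next structure is compound 4 `CN(Cc1ccccc1)C(=O)C1CCN(C(=O)c2cc3ccccc3n2Cc2ccc(C(F)(F)F)cc2)CC1`, with the change (trifluoromethyl in place of hydrogen on an aromatic carbon). For the measured compounds named here, two measured steps bear on it, each exchanging hydrogen with another group on an aromatic carbon: a 1.3-fold lower number from compound 1 to compound 3 (0.13 log units; within the scatter) and a 1.5-fold lower number from compound 2 to compound 3 (0.18 log units; within the scatter). Both lie within the scatter, as does a 1.1-fold higher number from compound 1 to compound 2 (0.06 log units; within the scatter). No step beyond the scatter is therefore expected in this assay. The expected change is a 1.3-fold higher number from compound 3 to compound 4 (0.12 log units; within the scatter). Compound 4 is estimated at 85000 nM, with an expected range of 50000 nM to 140000 nM.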

Compound 4, half-maximal cytotoxic concentration: 90300 nM
For compound 4 the middle estimate is 1.1-fold (0.03 log units) below the measured one, within the range that was stated.
By their numbers in this assay, from the lowest: compounds 3, 1, 4 and 2 (each within the scatter of the next).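

In this assay, the larger trifluoromethyl group, with its four heavy atoms, also stays within the scatter of all three earlier groups on this aromatic carbon: hydrogen (a 1.4-fold higher number from compound 3 to compound 4 (0.14 log units; within the scatter)), methoxy (a 1.1-fold lower number from compound 2 to compound 4 (0.04 log units; within the scatter)) and chloro (a 1.0-fold higher number from compound 1 to compound 4 (0.02 log units; within the scatter)). These four groups therefore cannot be ranked at this position, and none of the changes between them gives a step beyond the scatter. Nothing available gives a reason for this. Going by these compounds, it remains open whether an amine or a carboxylic acid on this carbon would give a step beyond the scatter.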